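Swapping an Iodophenyl for a Chlorosulfophenyl Group

The source may hold more compounds than are shown below. What is called first, only, known or untested is meant among the compounds shown, and "the series" means these compounds.

Of the compounds shown here, three have been measured in an assay on BaF3 cells with thrombopoietin receptor (Homo sapiens) as the target, read by a luciferase reporter; on this read-out lower numbers stand for smaller maximal responses and higher numbers for larger maximal responses. Compound 1 `O=[N+]([O-])c1cc(O)c(/N=N/c2c(O)ccc3ccccc23)c2ccccc12` reaches only a limit of this assay, < 5%. Compound 2 `O=C(Nc1c(O)cc(S(=O)(=O)O)c2ccccc12)c1c(O)ccc2ccccc12` likewise gives just a limit, < 5%. Within the data shown here, compound 3 `Cc1[nH]n(-c2ccc(I)cc2)c(=O)c1/N=N/c1c(O)cc(S(=O)(=O)O)c2ccccc12` is the single compound with an actual number, 81% in this assay, which sets it clearly apart from the limit of < 5% in this assay, at which 2 of the 3 values shown sit, where the other two remain.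

Compound 4 `Cc1[nH]n(-c2cc(S(=O)(=O)O)ccc2Cl)c(=O)c1/N=N/c1c(O)cc(S(=O)(=O)O)c2ccccc12` has not yet been measured. It differs from compound 3 in one place: 2-chloro-5-sulfophenyl in place of 4-iodophenyl on an aromatic nitrogen. Among the measured compounds shown here, no measured pair shows how such a change plays out here, so the expected step in this assay, a number 16 percentage points lower from compound 3 to compound 4 (beyond the scatter), is a modest fall that may well stay within the usual scatter. Compound 4 is therefore estimated at 65%, within a range from 25% to 95%.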

Compound 4, largest response reached (reported as efficacy), in percent of the reference or control that the assay uses: < 5%
Compound 4: only a limit was reported; the forecaster's own chance of this, stated with the estimate: 15%; middle value at least 60 percentage points away from the limit.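

This position matters greatly in this assay: with the rest of the molecule unchanged, 2-chloro-5-sulfophenyl in place of 4-iodophenyl gives a number at least 76 percentage points lower from compound 3 to compound 4 (beyond the scatter). The shared core alone therefore does not carry the response. Compound 4 reaches only a limit of the read-out, not a number, and joins the most common result in the set: the limit of < 5% in this assay, at which 3 of the 4 values shown sit.

On these data alone, the change removes the iodine and adds a chlorine and a sulfo group at once, so which of these counts remains open. Also open, as far as these compounds go, is how a phenyl ring bearing a carboxylic acid or an amine would behave at this position.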